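Replacing the ether oxygen in the side chain with carbon

The source may hold more compounds than are shown below. What is called first, only, known or untested is meant among the compounds shown, and "the series" means these compounds.

Of the compounds shown here, two of a shared core have been tested. Compound 1 `CCOCCn1c(N2CCN(C)CC2)nc2ccccc21` gives 10 nM in a functional assay on ileum for inhibition of histamine H1 receptor (Cavia porcellus) (on this read-out higher numbers stand for weaker inhibition and lower numbers for stronger inhibition), and compound 2 `CCCOCCn1c(N2CCN(C)CC2)nc2ccccc21` gives 20 nM in this assay; the step of a 2.0-fold higher number from compound 1 to compound 2 (0.30 log units; within the scatter) is within the scatter, so compound 2 is not separated from compound 1. Compound 3 `CCCCCCCn1c(N2CCN(C)CC2)nc2ccccc21` differs from compound 2 by pentyl in place of propoxy on a saturated chain carbon, two bonds along the chain from an aromatic nitrogen. Going by the values given here, only the step from compound 1 to compound 2 bears on this, and it stayed within the scatter; the loss of the oxygen is not covered by any measured step. For compound 3 the expected step is a 1.5-fold higher number from compound 2 to compound 3 (0.18 log units; within the scatter), and compound 3 is estimated at 30 nM, within 8 nM to 120 nM.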

Compound 3, half-maximal inhibitory concentration: 150 nM
Beside the measured number, compound 3's estimate is 5.0-fold (0.70 log units) below it, outside the stated range (above it).
By their numbers in this assay, from the lowest: compounds 1 and 2 (each within the scatter of the next); then compound 3.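

Swapping propoxy for pentyl gives a clear loss of inhibition in this assay, with a 7.5-fold higher number from compound 2 to compound 3 (0.88 log units; beyond the scatter), and pentyl in place of ethoxy gives a 15-fold higher number from compound 1 to compound 3 (1.18 log units; beyond the scatter). The all-carbon chain at this position is therefore separated from both ether chains, which the earlier pair, lying within the scatter, did not show. No measurement here explains the loss.

Pentyl also carries one more heavy atom than propoxy, so losing the oxygen and adding chain length remain untangled. A butyl chain here, or an amine in the oxygen's place, would help separate them.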